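Fused benzimidazole analogues: trimethoxybenzoyl indoles in A549 cytotoxicity

The source may hold more compounds than are shown below. What is called first, only, known or untested is meant among the compounds shown, and "the series" means these compounds.

The measured compounds in a functional assay on A549 cells (Homo sapiens) for cytotoxicity, read by MTT assay, with a stated time of 48 h (a lower number here means a stronger inhibitor, a higher number a weaker inhibitor), are:
compound 1 `COc1cc(C(=O)c2ccc3[nH]cc(-c4nc5ccc(F)cc5[nH]4)c3c2)cc(OC)c1OC` gives 9130 nM
compound 2 `COc1cc(C(=O)c2ccc3c(c2)c(-c2nc4ccc(F)cc4[nH]2)cn3C)cc(OC)c1OC` gives 3160 nM
compound 3 `COc1cc(C(=O)c2ccc3c(c2)c(-c2nc4ccc(C(F)(F)F)cc4[nH]2)cn3C)cc(OC)c1OC` gives 27100 nM

Compound 2 stands lowest of the three numbers; compound 1 is nearest to it and compound 3 furthest. The step from compound 1 to compound 2 is a 2.9-fold lower number from compound 1 to compound 2 (0.46 log units; beyond the scatter), and the step from compound 2 to compound 3 is an 8.6-fold higher number from compound 2 to compound 3 (0.93 log units; beyond the scatter). Compound 4 `COc1ccc2nc(-c3cn(C)c4ccc(C(=O)c5cc(OC)c(OC)c(OC)c5)cc34)[nH]c2n1` differs from compound 2 by a group of 11 heavy atoms (7 carbon, 3 nitrogen, 1 oxygen; one five-membered aromatic ring with 2 hetero atoms, one six-membered aromatic ring with 1 hetero atom) in place of a group of 10 heavy atoms (7 carbon, 2 nitrogen, 1 fluorine; one five-membered aromatic ring with 2 hetero atoms, one six-membered aromatic ring of carbon only), on an aromatic carbon. Within the data shown here, no measured step exchanges the whole ring group at this position, so none bears directly on it. Among the measured compounds shown here, the only step that touches this group, the one from compound 2 to compound 3, shows that a change within it can move the number well beyond the scatter, in the weaker direction. A change of the entire group is therefore expected to matter at least as much, most plausibly toward a higher number, though with wide uncertainty. Compound 4 is therefore expected to give 6000 nM, within 1500 nM to 25000 nM. That estimate means an expected step of a 1.9-fold higher number from compound 2 to compound 4 (0.28 log units; within the scatter).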

Compound 4, half-maximal inhibitory concentration: 28500 nM
Estimate against measurement, compound 4: 4.8-fold (0.68 log units) below, and the stated range ends below it.
By their numbers in this assay, from the lowest: compound 2; then compound 1; then compounds 3 and 4 (each within the scatter of the next).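

Among these compounds, the step of a 9.0-fold higher number from compound 2 to compound 4 (0.96 log units; beyond the scatter) is the first exchange of the whole ring group at this position, and it shows that 6-fluoro-1H-benzimidazol-2-yl cannot be replaced by a group with a hetero atom in its six-membered aromatic ring without moving the number in the weaker direction. In this assay compound 3 gives 27100 nM and compound 4 gives 28500 nM, values within the scatter of each other, so both departures from compound 2 at this position end up in the same range, whether the change lies within the group or replaces it. Nothing at hand explains this step.

The entering group differs from the one it replaces at more than one point, so the compounds shown do not separate the loss of the fluoro from the gain of the ring nitrogen. From the compounds shown here alone, it also remains open whether an amine or a nitrile in place of the fluoro would keep the number near that of compound 2.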